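This account rests on a few compounds, and the source may have more. Where it says the series, first, only, none or still open, it means among the compounds named here.

Measured so far in an assay on isolated protein for inhibition of receptor-type tyrosine-protein phosphatase C (Homo sapiens), read by spectrophotometry; a lower number here means a stronger inhibitor, a higher number a weaker inhibitor:
compound 1 `O=C(COc1ccc2cc(C(O)(C(F)(F)F)C(F)(F)F)c(O)cc2c1)Nc1nc2ccccc2s1` gives 10900 nM.
compound 2 `CCCNC(=O)COc1ccc2cc(C(O)(C(F)(F)F)C(F)(F)F)c(O)cc2c1` gives > 20000 nM, a limit of the assay.
compound 3 `COc1ccc(CNC(=O)COc2ccc3cc(C(O)(C(F)(F)F)C(F)(F)F)c(O)cc3c2)cc1OC` gives > 20000 nM, likewise a limit of the assay.

Compound 3 therefore stands at the limit of > 20000 nM in this assay, at which 2 of the 3 values shown sit, and its own number is not read. Compound 4 `O=C(COc1ccc2cc(C(O)(C(F)(F)F)C(F)(F)F)c(O)cc2c1)NCc1ccccc1` differs from compound 3 by phenyl in place of 3,4-dimethoxyphenyl on a saturated chain carbon bound to an amide-type nitrogen. Going by the values given here, the steps measured bear on this only loosely: an at least 1.8-fold higher number from compound 1 to compound 2 (0.26 log units; that floor lies within the scatter) and an at least 1.8-fold higher number from compound 1 to compound 3 (0.26 log units; that floor lies within the scatter) are floors, and a step that the two limits leave unreadable from compound 2 to compound 3 is the one change at this same place, yet its size cannot be read. Among the compounds with values here, no measured step shows a change beyond the scatter in this assay . Compound 4 is expected to give a number no higher from compound 3 to compound 4 (the limit leaves the size open). Compound 4 is estimated at 20000 nM, with a range from 9000 nM to 45000 nM.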

Compound 4, half-maximal inhibitory concentration: > 20000 nM
Compound 4 was reported as a limit; the forecaster's own chance of this, stated with the estimate: 60%; the middle value lies on the limit itself.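

In this assay compound 4 gives > 20000 nM, a limit of the assay. The steps among compound 2, compound 3 and compound 4 cannot be read, so phenyl, 3,4-dimethoxyphenyl and ethyl on this saturated chain carbon are not told apart: the limit of > 20000 nM in this assay, at which 3 of the 4 values shown sit. Going by these compounds alone, the only readable new step, benzyl in place of 1,3-benzothiazol-2-yl on the amide-type nitrogen, is an at least 1.8-fold higher number from compound 1 to compound 4 (0.26 log units; that floor lies within the scatter).

As far as these compounds go, whether a carboxylic acid or an amine on the benzyl group brings a number under that limit stays open. So does whether a plain phenyl or a pyridin-2-yl on the amide-type nitrogen would match compound 1.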